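The source may hold more compounds than are shown below. What is called first, only, known or untested is meant among the compounds shown, and "the series" means these compounds.

Values in a functional assay on SK-N-SH cells (Homo sapiens) for cytotoxicity, read by MTT assay, with a stated time of 24 h (a higher number here means a weaker inhibitor, a lower number a stronger inhibitor), for the series:
compound 1 `C/C(=N\NC(=O)/C(C#N)=C/c1ccccc1)c1c(O)c2ccc(O)cc2oc1=O` gives 13500 nM here
compound 2 `COc1ccc(/C=C(\C#N)C(=O)N/N=C(\C)c2c(O)c3ccc(O)cc3oc2=O)cc1OC` gives 21500 nM here

Going by the values given here, compound 2 stands within the scatter of the only other number. Compound 3 `COc1cc(/C=C(\C#N)C(=O)N/N=C(\C)c2c(O)c3ccc(O)cc3oc2=O)cc(OC)c1OC` differs from compound 2 by methoxy in place of hydrogen on an aromatic carbon and so carries methoxy in place of hydrogen on an aromatic carbon, ortho to a methoxy group. Among the compounds with values here, one measured step bears on this. Since the step of a 1.6-fold higher number from compound 1 to compound 2 (0.20 log units; within the scatter) with 3,4-dimethoxyphenyl in place of phenyl stayed within the scatter, no step beyond the scatter is expected in this assay for this change. The expected step is a 1.1-fold lower number from compound 2 to compound 3 (0.03 log units; within the scatter) in size. For compound 3 the estimated value is 20000 nM with 9000 nM to 42000 nM as the expected range.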

Compound 3, half-maximal inhibitory concentration: 14600 nM
Beside the measured number, compound 3's estimate is 1.4-fold (0.14 log units) above it; the range from low to high includes it.
By their numbers in this assay, from the lowest: compounds 1, 3 and 2 (each within the scatter of the next).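

In this assay, methoxy in place of hydrogen on an aromatic carbon, ortho to a methoxy group, gives a 1.5-fold lower number from compound 2 to compound 3 (0.17 log units; within the scatter) and stays within the scatter. The 3,4-dimethoxyphenyl ring of compound 2 therefore accepts a further methoxy at this position without a measurable shift, extending what a 1.6-fold higher number from compound 1 to compound 2 (0.20 log units; within the scatter) showed for the phenyl ring of compound 1. No measurement at hand explains this result.

At this position, only hydrogen and methoxy are compared. From the compounds shown here alone, whether an amine or a carboxylic acid there would give a step beyond the scatter remains open.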